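The source may report more compounds than this note shows. Statements on the series, on what has been measured and on what is new or still open speak of the compounds shown alone.

Working notes on the series. Compound 1 `CCCC(CCC)Nc1nc(C)nc2c1nnn2-c1ccc(Br)cc1Br` gives 0.8 nM in an in vitro assay on 293-EBNA cells for binding affinity to corticotropin-releasing factor receptor 1 (Homo sapiens); on this read-out lower numbers stand for stronger inhibition and higher numbers for weaker inhibition. Compound 2 `CCN(c1nc(C)nc2c1nnn2-c1ccc(C(C)C)cc1Br)C(COC)COC` gives 123 nM in this assay. Compound 3 `CCCCN(CC)c1nc(C)nc2c1nnn2-c1ccc(Br)cc1Br` gives 20.4 nM in this assay, the second highest of the three numbers: compound 2 stands somewhat higher, and compound 1 stands well lower, the gap being a 26-fold higher number from compound 1 to compound 3 (1.41 log units; beyond the scatter) and arising from butyl(ethyl)amino in place of (1-propylbutyl)amino on an aromatic carbon.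

Compound 4 `CCCCN(CC)c1nc(C)nc2c1nnn2-c1ccc(S(C)(=O)=O)cc1Br` differs from compound 3 by methylsulfonyl in place of bromo on an aromatic carbon. For the measured compounds named here, no measured step bears on this change: the single step in hand concerns the amino group, not the substituent on the aryl ring, and compound 2 differs from compound 3 in more than one place, so its number gives no isolated reading. The expectation therefore rests on weak footing. The step from compound 3 to compound 4 is expected to be a 2.9-fold higher number from compound 3 to compound 4 (0.47 log units; beyond the scatter), toward a higher number. Compound 4 is estimated at 60 nM, with a range from 10 nM to 400 nM.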

Compound 4, inhibition constant: 100 nM
For compound 4 the middle estimate is 1.7-fold (0.22 log units) below the measured one, within the range that was stated.
By their numbers in this assay, from the lowest: compound 1; then compound 3; then compounds 4 and 2 (each within the scatter of the next).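

The position meta to a bromo group and para to a large group now has its first isolated reading. In this assay, a 4.9-fold higher number from compound 3 to compound 4 (0.69 log units; beyond the scatter) accompanies the exchange of bromo (1 heavy atom, no hydrogen-bond acceptors) for methylsulfonyl (4 heavy atoms, 2 hydrogen-bond acceptors), so this position affects the read-out, though with a modest step where the amino change in a 26-fold higher number from compound 1 to compound 3 (1.41 log units; beyond the scatter) was large. Nothing at hand accounts for the rise.

From the compounds shown here alone, whether the step follows the added heavy atoms or the acceptors stays open, and a methyl, methoxy or nitrile group at this position would help separate the two. Also open, going by these compounds, is whether methylsulfonyl in place of bromo gives a similar step with the (1-propylbutyl)amino group of compound 1.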